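This account rests on a few compounds, and the source may have more. Where it says the series, first, only, none or still open, it means among the compounds named here.

Compound 2, with the structure `CCN(CC)C(=O)CN(c1ccc(C)cc1)S(=O)(=O)c1ccc(OC)cc1`, belongs to a small set of sulfonamides built around one shared core. In a functional assay on CHO cells for inhibition of Orexin/Hypocretin receptor type 1 (Homo sapiens), read by FLIPR and calcium flux (on this read-out lower numbers stand for stronger inhibition and higher numbers for weaker inhibition), compound 2 gives only a limit, > 10000 nM, and not a number. Compound 1, the structure `CCN(CC)C(=O)CN(c1ccc(C)cc1)S(=O)(=O)c1ccc(OC)c(OC)c1`, likewise returns a limit in this assay, > 10000 nM. Compound 3, the structure `CCN(CC)C(=O)CN(c1cc(N(C)C)ccc1OC)S(=O)(=O)c1ccc(OC)c(OC)c1`, also gives a limit in this assay, > 10000 nM. Compound 2 therefore stands at the limit shared by every value in the set, as the evidence the limit of > 10000 nM in this assay, at which 3 of the 3 values shown sit, records. The two measured steps that touch this series, a step that the two limits leave unreadable from compound 1 to compound 2 and a step that the two limits leave unreadable from compound 1 to compound 3, run between limits and give no readable size, so neither shows what a change on the sulfonyl aryl group does in this assay.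

Compound 4, the structure `CCN(CC)C(=O)CN(c1ccc(C)cc1)S(=O)(=O)c1ccccc1C`, is not yet measured. The change from compound 2 to compound 4 is 2-methylphenyl in place of 4-methoxyphenyl on a sulfonyl sulfur. Among the measured compounds shown here, no measured step bears on it in a readable way, and nothing among the three compounds shows any value inside the measurable range. On that basis compound 4 is expected to remain at the limit, so that the estimated step that the limit leaves unreadable from compound 2 to compound 4 is essentially none beyond the scatter. The estimate for compound 4 in this assay is 20000 nM, with a range from 6000 nM to 100000 nM.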

Compound 4, half-maximal inhibitory concentration: > 10000 nM
Compound 4: only a limit was reported; the forecaster's own chance of this, stated with the estimate: 80%; the middle value is on the limit's open side.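

In this assay compound 4 gives > 10000 nM, which is a limit and not a number. Compound 2 also stands at a limit, so no step can be read from compound 2 to compound 4. The compounds shown leave open whether any change to the shared core gives a measurable value in this assay.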